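The source may hold more compounds than are shown below. What is called first, only, known or untested is meant among the compounds shown, and "the series" means these compounds.

Working notes on the series. The shared core of compound 1 `N#Cc1c(Nc2cccc(C(F)(F)F)c2)nc(SCc2cn(Cc3ccccc3Cl)nn2)nc1-c1ccccc1` carries the aniline nitrogen as the point of variation, and in a functional assay on ECa-109 cells (Homo sapiens) for inhibition, read by MTT assay, with a stated time of 72 h (on this read-out lower numbers stand for stronger inhibition and higher numbers for weaker inhibition), compound 1 gives 32000 nM. Compound 2 `N#Cc1c(Nc2ccccc2)nc(SCc2cn(Cc3ccccc3Cl)nn2)nc1-c1ccccc1` in this assay returns only a limit of the assay, > 64000 nM. Compound 3 `Cc1ccc(Nc2nc(SCc3cn(Cc4ccccc4Cl)nn3)nc(-c3ccccc3)c2C#N)cc1` in this assay likewise returns a limit, > 64000 nM. The steps of an at least 2.0-fold higher number from compound 1 to compound 2 (0.30 log units; that floor lies within the scatter) and an at least 2.0-fold higher number from compound 1 to compound 3 (0.30 log units; that floor lies within the scatter) carry only a floor, and a step that the two limits leave unreadable from compound 2 to compound 3 cannot be read, because of the limit of > 64000 nM in this assay, at which 2 of the 3 values shown sit. Compound 3 therefore stands at the limit among the values shown, with no number of its own.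

Compound 4 `Cc1ccc(Nc2nc(SCc3cn(Cc4ccccc4Cl)nn3)nc(-c3ccc(Br)cc3)c2C#N)cc1` differs from compound 3 by bromo in place of hydrogen on an aromatic carbon. All three measured steps alter the aniline part and leave the phenyl untouched, so none of them bears on this change, and no step size can be carried over. The expectation for compound 4 in this assay rests on compound 3 alone, whose read-out is > 64000 nM. Compound 4 is expected at 70000 nM, with a range from 20000 nM to 200000 nM. The estimated step that the limit leaves unreadable from compound 3 to compound 4 is thus an expectation without a measured anchor, and a further limit rather than a number is the more likely outcome.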

Compound 4, half-maximal inhibitory concentration: 3090 nM
Compound 4: middle estimate off by 23-fold (1.36 log units), on the high side; the whole stated range lies above it.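

Bromo in place of hydrogen on the phenyl, on an aromatic carbon para to a large group, gives in this assay an at least 20-fold lower number from compound 3 to compound 4 (1.31 log units; beyond the scatter); this position therefore responds strongly to a single added heavy atom. Going by these compounds alone, the earlier steps, all in the aniline part, gave only floors within the scatter or could not be read, so this is the first step printed as beyond the scatter, and it comes from the phenyl rather than from the aniline nitrogen substituent. Its true size remains a floor, because compound 3 has only a limit of the assay and no number of its own: the limit of > 64000 nM in this assay, at which 2 of the 4 values shown sit.

The compounds shown leave open whether the change depends on bromine itself or would also hold for chloro, methoxy or a carboxylic acid at the same carbon. They also leave open whether 4-bromophenyl would give a similar step with the 3-(trifluoromethyl)phenyl group of compound 1 or the unsubstituted aniline of compound 2 in place of the 4-methylphenyl group.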